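The source may hold more compounds than are shown below. What is called first, only, known or untested is meant among the compounds shown, and "the series" means these compounds.

Three compounds share one core and differ only in the ring attached to the carbonyl carbon of the amide. Compound 1 `O=C(CC1CCCCC1)N1CCN(c2nc(=O)c3cc(C(F)(F)F)cc([N+](=O)[O-])c3s2)CC1` carries a cyclohexylmethyl there, compound 2 `O=C(C1CCCC1)N1CCN(c2nc(=O)c3cc(C(F)(F)F)cc([N+](=O)[O-])c3s2)CC1` a cyclopentyl and compound 3 `O=C(C1CCC1)N1CCN(c2nc(=O)c3cc(C(F)(F)F)cc([N+](=O)[O-])c3s2)CC1` a cyclobutyl. In an ADME assay on Vero cells (Chlorocebus sabaeus) for cytotoxicity, read by MTT assay, with a stated time of 72 h (on this read-out lower numbers stand for higher toxicity in this test and higher numbers for lower toxicity in this test), compound 1 reaches only the limit of > 125000 nM. Compound 2 gives 120000 nM in this assay. Compound 3 likewise stops at the limit of > 125000 nM in this assay. Compound 3 thus sits at the ceiling, which is the limit of > 125000 nM in this assay, at which 2 of the 3 values shown sit. The step that the two limits leave unreadable from compound 1 to compound 3 cannot be read, while an at least 1.0-fold higher number from compound 2 to compound 3 (0.01 log units; that floor lies within the scatter) and an at least 1.0-fold lower number from compound 1 to compound 2 (0.01 log units; that floor lies within the scatter) stay within the scatter. Compound 4 `CC(C)(C)C1CCC(C(=O)N2CCN(c3nc(=O)c4cc(C(F)(F)F)cc([N+](=O)[O-])c4s3)CC2)CC1` brings (4-(tert-butyl)cyclohexyl in place of cyclobutyl on a carbonyl carbon). Since every measured step is flat, no change beyond the scatter is expected, a number no higher from compound 3 to compound 4 (the limit leaves the size open). Compound 4 is therefore expected near 125000 nM, between 90000 nM and 125000 nM.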

Compound 4, half-maximal cytotoxic concentration: > 125000 nM
Compound 4 was reported as a limit; the forecaster's own chance of this, stated with the estimate: 75%; the middle value lies on the limit itself.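

Even with 4-(tert-butyl)cyclohexyl on the carbonyl carbon, a group with more heavy atoms than cyclobutyl, compound 4 gives > 125000 nM in this assay, and this is a limit, not a number. Within the data shown here, the one readable step is an at least 1.0-fold higher number from compound 2 to compound 4 (0.01 log units; that floor lies within the scatter), while the steps joining two limits cannot be read. A much bulkier ring therefore brings no readable drop, and compound 4 joins the ceiling: the limit of > 125000 nM in this assay, at which 3 of the 4 values shown sit. Going by these compounds, whether an amine or a carboxylic acid on the carbonyl carbon would lower the number in this assay stays open. Any real differences among the compounds at the limit also stay hidden.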